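A few compounds are considered here, and "the series" means these few. Any claim that something is new, unique, unknown or untested is made for them only; others in the source may bear on it.

In a functional assay on HeLa cells (Homo sapiens) for inhibition, read by MTT assay, with a stated time of 72 h (a lower number here means a stronger inhibitor, a higher number a weaker inhibitor), the three measured compounds read as follows:
compound 1 `C/C=C/C(=O)Nc1cccc(Oc2nc(Nc3cccc(OC)c3)nc3ccsc23)c1` gives 20100 nM;
compound 2 `COc1cccc(Nc2nc(Oc3cccc(NC(=O)C=C(C)C)c3)c3sccc3n2)c1` gives 26100 nM;
compound 3 `C/C=C/C(=O)Nc1cccc(Oc2nc(Nc3cccc(C#N)c3)nc3ccsc23)c1` gives 23600 nM.

All three numbers lie within the usual scatter of one another, so no order among them can be read from these data. Compound 4 `CC(C)=CC(=O)Nc1cccc(Oc2nc(Nc3cccc(C#N)c3)nc3ccsc23)c1` has not yet been measured. It differs from compound 3 in one place: 2-methylprop-1-en-1-yl in place of prop-1-en-1-yl on a carbonyl carbon. The same change has already been made once, from compound 1 to compound 2: 2-methylprop-1-en-1-yl in place of prop-1-en-1-yl on a carbonyl carbon, and it gave a 1.3-fold higher number from compound 1 to compound 2 (0.11 log units; within the scatter). The two cores differ elsewhere, by cyano in place of methoxy on an aromatic carbon, a change that gave a 1.2-fold higher number from compound 1 to compound 3 (0.07 log units; within the scatter). Since the place of the change is identical in both pairs, the step from compound 3 to compound 4 is estimated as a 1.3-fold higher number from compound 3 to compound 4 (0.10 log units; within the scatter), a step of about the same size as the earlier one, because that earlier step gave a 1.3-fold higher number from compound 1 to compound 2 (0.11 log units; within the scatter). Compound 4 is therefore expected to give 30000 nM in this assay. The estimate for compound 4 is expected to fall between 15000 nM and 60000 nM.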

Compound 4, half-maximal inhibitory concentration: 19800 nM
For compound 4 the middle estimate is 1.5-fold (0.18 log units) above the measured one; low and high end bracket the measured number.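

In this assay, 2-methylprop-1-en-1-yl in place of prop-1-en-1-yl on a carbonyl carbon gives a 1.2-fold lower number from compound 3 to compound 4 (0.08 log units; within the scatter), and the step matches the earlier one on the other core as far as these data can tell: the same change on two cores in this assay, a 1.3-fold higher number (0.11 log units; within the scatter) from compound 1 to compound 2 and a 1.2-fold lower number (0.08 log units; within the scatter) from compound 3 to compound 4, 1.5-fold (0.19 log units) apart, within the scatter of two such steps. Cyano in place of methoxy on an aromatic carbon gives a 1.3-fold lower number from compound 2 to compound 4 (0.12 log units; within the scatter), and the same holds for this change: the same change on two cores in this assay, a 1.2-fold higher number (0.07 log units; within the scatter) from compound 1 to compound 3 and a 1.3-fold lower number (0.12 log units; within the scatter) from compound 2 to compound 4, 1.5-fold (0.19 log units) apart, within the scatter of two such steps. All of these steps lie within the scatter, so the four compounds show that neither change carries a measurable step on these cores, but they do not show how a step of real size would carry from one core to another.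

Open, going by these compounds, is whether an amine or a longer chain on the carbonyl carbon would give a step beyond the scatter. The same question stands for a carboxylic acid or a halogen on the aromatic carbon that holds the cyano or methoxy.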